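The source may hold more compounds than are shown below. What is called first, only, known or untested is meant among the compounds shown, and "the series" means these compounds.

Of the compounds shown here, three built on one shared core have been tested in a functional assay on L1210 cells (Mus musculus), with a stated time of 12 days; a lower number here means a less potent compound, a higher number a more potent compound, by a factor of ten per unit of this negative logarithm. Compound 1 `CC1=C(N2CC2)C(=O)C(CCCOC(N)=O)=C(N2CC2)C1=O` gives 6.18. Compound 2 `CC1=C(N2CC2)C(=O)C(C(C)C)=C(N2CC2)C1=O` gives 5.6, and compound 3 `CC1=C(N2CC2)C(=O)C(C2CCCCC2)=C(N2CC2)C1=O` gives 5.82. Compound 2 stands lowest of the three numbers: going from the longer chain of compound 1 to the isopropyl group of compound 2 there is a number 0.58 log units lower from compound 1 to compound 2 (beyond the scatter), and going on to the ring of compound 3 there is a number 0.22 log units higher from compound 2 to compound 3 (within the scatter). From compound 1 to compound 3 there is likewise a number 0.36 log units lower from compound 1 to compound 3 (beyond the scatter).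

The next compound, compound 4 `CC(C)C1=C(N2CC2)C(=O)C=C(N2CC2)C1=O`, differs from compound 2 in another spot: hydrogen in place of methyl on a double-bonded ring carbon. None of the three measured steps bears on this change. Each of them swaps the group on the other substituted ring carbon while the methyl stays in place, so the data give no direct guide to what removing the methyl does. Going by the values given here, with no step to lean on, the expectation is a move of small size, if any, in either direction. Compound 4 is therefore expected to give about 5.55, within a range from 5 to 6.1. This expectation amounts to a step of a number 0.05 log units lower from compound 2 to compound 4 (within the scatter), which would lie within the scatter.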

Compound 4, logarithm of the reciprocal of the active concentration, log(1/C): 5.68
Compound 4: middle estimate off by 0.13 log units, on the low side, within the range that was stated.
By their numbers in this assay, from the lowest: compounds 2, 4 and 3 (each within the scatter of the next); then compound 1.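

Going by these compounds alone, until this pair, the methyl on this double-bonded ring carbon had stayed in place in every compound, so this is the first reading of that position. In this assay, hydrogen in place of methyl gives a number 0.08 log units higher from compound 2 to compound 4 (within the scatter) and so leaves the two compounds indistinguishable, with the isopropyl group and both aziridin-1-yl groups held fixed. For this one pair, then, the methyl is not needed to keep the number where it stands, and no measurement at hand offers an explanation of this result.

The compounds shown leave open what other groups on this carbon would do, such as an ethyl group, a methoxy group, an amine or a chlorine atom, since hydrogen and methyl are the only two seen here. From the compounds shown here alone, it also remains open whether hydrogen in place of methyl would give an equally small step with the cyclohexyl group of compound 3 or the longer chain of compound 1 on the other substituted ring carbon.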